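Swapping the sulfonyl substituent in a macrocyclic series

The source may report more compounds than this note shows. Statements on the series, on what has been measured and on what is new or still open speak of the compounds shown alone.

Compound 1 `COc1ccc2c(OCC[C@@H]3NC(=O)N(C)CCCC/C=C\[C@@H]4C[C@@]4(C(=O)NS(=O)(=O)N(C)C)NC3=O)cc(-c3nc(C(C)C)cs3)nc2c1Cl`, 47800 nM.
Compound 2 `C#C[C@@H]1CCCN1S(=O)(=O)NC(=O)[C@@]12C[C@H]1/C=C\CCCCN(C)C(=O)N[C@@H](CCOc1cc(-c3nc(C(C)C)cs3)nc3c(Cl)c(OC)ccc13)C(=O)N2`, 21200 nM.
Compound 3 `COc1ccc2c(OCC[C@@H]3NC(=O)N(C)CCCCC/C=C\[C@@H]4C[C@@]4(C(=O)NS(=O)(=O)C4CC4)NC3=O)cc(-c3ccccc3)nc2c1`, 53000 nM.

All three compounds were tested in an ADME assay on cells (Homo sapiens) for activation; a higher number here means that more compound is tolerated, a lower number that less compound is tolerated. Compound 1 stands second highest of the three numbers; compound 3 lies within the scatter of it, and compound 2 sits furthest away, with a 2.3-fold lower number from compound 1 to compound 2 (0.35 log units; beyond the scatter).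

Compound 4 `COc1ccc2c(OCC[C@@H]3NC(=O)N(C)CCCC/C=C\[C@@H]4C[C@@]4(C(=O)NS(=O)(=O)C4(C#N)CC4)NC3=O)cc(-c3nc(C(C)C)cs3)nc2c1Cl` differs from compound 1 in one place: 1-cyanocyclopropyl in place of dimethylamino on a sulfonyl sulfur. Within the data shown here, the only measured step at the same place is the one from compound 1 to compound 2, where a ring-bearing group replaced dimethylamino and the number fell modestly. Compound 3 carries a different group at this position but also a different core, so its value speaks only indirectly. The replacement in compound 4 is a different ring-bearing group from that of compound 2, so the earlier step is a loose guide rather than a direct precedent. A modest lowering, or no step beyond the scatter, is therefore expected, as a 1.4-fold lower number from compound 1 to compound 4 (0.14 log units; within the scatter). For compound 4 the estimated value in this assay is 35000 nM, with a likely range from 15000 nM to 75000 nM.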

Compound 4, half-maximal cytotoxic concentration: > 75000 nM
Compound 4: only a limit was reported; the forecaster's own chance of this, stated with the estimate: 15%; middle value at least 2.1-fold (0.33 log units) away from the limit.
By their numbers in this assay, from the lowest: compound 2; then compounds 1 and 3 (each within the scatter of the next). At a limit, above all of these: compound 4.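

In this assay compound 4 gave only a limit, not a number: the limit of > 75000 nM in this assay, at which 1 of the 4 values shown sits. The earlier compounds had shown only a fall at this place on the sulfonyl sulfur, yet the new result shows that replacing dimethylamino need not lower the number, with an at least 1.5-fold higher number from compound 1 to compound 4 (0.19 log units; that floor lies within the scatter); the floor of this step does not separate the two compounds. The clearer contrast is between the two ring-bearing groups, with an at least 3.5-fold higher number from compound 2 to compound 4 (0.54 log units; beyond the scatter), so carrying a ring does not by itself set the outcome at this place, and 1-cyanocyclopropyl is tolerated better than 2-ethynylpyrrolidin-1-yl on this core.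

As far as these compounds go, how far the true number of compound 4 lies past its limit remains open, and with it whether this compound really differs from compound 1. Also open, from the compounds shown here alone, is how a plain cyclopropyl without the nitrile, or a pyrrolidin-1-yl without the ethynyl, would behave on the same sulfonyl sulfur of the shared core, so the share of the ring and the share of the nitrile or ethynyl group in these steps cannot yet be separated.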